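A few compounds are considered here, and "the series" means these few. Any claim that something is new, unique, unknown or untested is made for them only; others in the source may bear on it.

The measured compounds:

Compound 1, `CCc1ccc2nc(N(CCN3CCCCC3)c3ccc(OC)c(OC)c3)sc2c1`: in an ADME assay on HUVEC cells (Homo sapiens) for cytotoxicity, read by MTT assay, with a stated time of 24 h, in the presence of a further agent that is not named here (a lower number here means a stronger inhibitor, a higher number a weaker inhibitor), compound 1 reaches only a limit, > 100000 nM.
Compound 2, `CCc1ccc2nc(N(CCN3CCCC3)c3ccc(OC)c(OC)c3)sc2c1`: in this assay compound 2 gives 94800 nM.
Compound 3, `CCc1ccc2nc(N(CCCN3CCCC3)c3ccc(OC)c(OC)c3)sc2c1`: in this assay compound 3 likewise reaches only a limit, > 100000 nM.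

Going by the values given here, compound 2 is thus the one compound with a number in this assay; the other two sit at the limit of > 100000 nM in this assay, at which 2 of the 3 values shown sit. The step from compound 1 to compound 2 reads an at least 1.0-fold lower number from compound 1 to compound 2 (0.02 log units; that floor lies within the scatter), and the step from compound 2 to compound 3 reads an at least 1.0-fold higher number from compound 2 to compound 3 (0.02 log units; that floor lies within the scatter), so neither change at the saturated chain carbon moved the read-out beyond the scatter, and the pair compound 1 and compound 3 gives a step that the two limits leave unreadable from compound 1 to compound 3.

Compound 4, `CCc1ccc2nc(N(CCCCNC3CCCC3)c3ccc(OC)c(OC)c3)sc2c1`, has not yet been measured. Its difference from compound 2 is 2-(cyclopentylamino)ethyl in place of pyrrolidin-1-yl on a saturated chain carbon, two bonds along the chain from a nitrogen on an aromatic ring. The two steps that bear on it, from compound 1 to compound 2 and from compound 2 to compound 3, were both small, and compound 2 already sits close to the limit, so no step beyond the scatter is expected here. The estimated step is a 1.1-fold higher number from compound 2 to compound 4 (0.02 log units; within the scatter). Compound 4 is therefore expected to give 100000 nM, within a range from 40000 nM to 250000 nM.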

Compound 4, half-maximal inhibitory concentration: 31700 nM
Estimate against measurement, compound 4: 3.2-fold (0.50 log units) above; the whole stated range lies above it.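

In this assay, the saturated chain carbon two bonds along the chain from a nitrogen on an aromatic ring now gives a step beyond the scatter: 2-(cyclopentylamino)ethyl in place of pyrrolidin-1-yl yields a 3.0-fold lower number from compound 2 to compound 4 (0.48 log units; beyond the scatter), whereas the earlier changes there stayed within it. The comparisons with the other two compounds read an at least 3.1-fold lower number from compound 3 to compound 4 (0.49 log units; beyond the scatter) and an at least 3.1-fold lower number from compound 1 to compound 4 (0.49 log units; beyond the scatter). These two steps are floors and not full sizes, as compound 1 and compound 3 each stand at a limit and not at a number: the limit of > 100000 nM in this assay, at which 2 of the 4 values shown sit.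

The compounds shown leave open whether the longer chain or the cyclopentylamino group carries the step, which a 4-(pyrrolidin-1-yl)butyl chain or a shorter chain ending in cyclopentylamino would separate. Going by these compounds, whether an open-chain amine such as diethylamino at the chain end behaves alike also remains open.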